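Working notes: phenyl in place of 1-methyl-1H-pyrazol-5-yl

This account rests on a few compounds, and the source may have more. Where it says the series, first, only, none or still open, it means among the compounds named here.

For the measured compounds named here, in a functional assay on NCI-H1993 cells (Homo sapiens) for inhibition, read by CCK-8 assay, with a stated time of 72 h (a higher number here means a weaker inhibitor, a lower number a stronger inhibitor), compound 3 (`Cn1nccc1-c1cnc2ncn(Cc3ccc4ncccc4c3)c2n1`) gives 7910 nM as the only number so far. In this assay compound 1 (`CCC(c1cc2cccnc2cc1F)n1cnc2ncc(-c3cnn(C)c3)nc21`) has "not determined" (no result reported) as its entry, and compound 2 (`CCC(c1ccc2ncccc2c1F)n1cnc2ncc(-c3ccccc3)nc21`) has "not determined" (no result reported) as its entry. Going by the values given here, with a single value, compound 3 cannot be ranked against any other compound, and no measured step is available to size a change on the shared core.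

The next compound for testing is compound 4 (`c1ccc(-c2cnc3ncn(Cc4ccc5ncccc5c4)c3n2)cc1`). It differs from compound 3 in one place, with phenyl in place of 1-methyl-1H-pyrazol-5-yl on an aromatic carbon of a six-membered aromatic ring with 2 nitrogen.

No step beyond the usual scatter is expected in this assay, and no direction is favoured. The estimated change is a 1.2-fold lower number from compound 3 to compound 4 (0.09 log units; within the scatter) and amounts to no clear gain or loss. Among the compounds with values here, this expectation has a single anchor in compound 3 at 7910 nM and no measured step behind it, so the range is kept wide. For compound 4 the expected value is 6500 nM within an estimated range (2000 nM to 20000 nM).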

Compound 4, half-maximal inhibitory concentration: 7490 nM
Compound 4: the middle estimate sits 1.2-fold (0.06 log units) below what was measured, and the stated range covers the measured number.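

For the compounds shown here, the first measured step on the shared core reads a 1.1-fold lower number from compound 3 to compound 4 (0.02 log units; within the scatter) in this assay, so at this aromatic carbon, next to the ring nitrogen, the values of the two compounds cannot be told apart. The exchange is not a small one on paper: a five-membered aromatic ring with 2 hetero atoms and 2 hydrogen-bond acceptors gives way to a six-membered aromatic ring of carbon only with 0 hydrogen-bond acceptors, at the same 6 heavy atoms, and this assay does not separate the pair. Nothing available accounts for this outcome, so the flat step stands as an observation on this one pair and not as a rule for the position.

Still open, as far as these compounds go, is whether any group at this carbon gives a step beyond the scatter, for instance a phenyl bearing a carboxylic acid or a dimethylamino group, or a saturated amine such as piperazine in place of the aromatic ring. From the compounds shown here alone, with only compound 3 and compound 4 carrying numbers, it is also open whether this flat step would hold on a different core, such as that of compound 1 or compound 2.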